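A few compounds are considered here, and "the series" means these few. Any claim that something is new, unique, unknown or untested is made for them only; others in the source may bear on it.

Measured in an ADME assay on L02 cells (Homo sapiens) for antiproliferative activity, read by CCK-8 assay, with a stated time of 6 days; on this read-out higher numbers stand for weaker inhibition and lower numbers for stronger inhibition:
compound 1 `CCN(c1cccc(-c2ccccc2)c1)c1ccc(C#N)c(Cl)c1` gives "not determined" (no result reported)
compound 2 `N#Cc1ccc(N2CCc3cc(-c4cnc5ccccc5c4)ccc32)cc1C(F)(F)F` gives "not determined" (no result reported)
compound 3 `CCN(c1ccc(C#N)c(Cl)c1)c1cc(-c2ccccc2)ccc1C` gives > 30000 nM

The entry for compound 3 is a limit and not a number (> 30000 nM). Within the data shown here, neither compound 1 nor compound 2 offers a number, so the series holds no measured step.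

Compound 4 `CCN(c1ccc(C#N)c(Cl)c1)c1cc(-n2ccnc2)ccc1C` differs from compound 3 by 1H-imidazol-1-yl in place of phenyl on an aromatic carbon, para to a methyl group (1H-imidazol-1-yl in place of phenyl on an aromatic carbon).

This expectation rests only on the limit of compound 3 (> 30000 nM). The expected step of a number no higher from compound 3 to compound 4 (the limit leaves the size open) stays within the scatter and has no favoured direction in this assay and another limit is the likely report. For compound 4 the estimated value is 30000 nM with 12000 nM to 60000 nM as the expected range.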

Compound 4, half-maximal inhibitory concentration: 15000 nM
For compound 4 the middle estimate is 2.0-fold (0.30 log units) above the measured one; the range from low to high includes it.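

In this assay, among these compounds, 1H-imidazol-1-yl in place of phenyl on the aromatic carbon para to a methyl group gives an at least 2.0-fold lower number from compound 3 to compound 4 (0.30 log units; that floor lies within the scatter), so this position now carries a first actual number. For compound 3 the entry > 30000 nM is a limit and not a number. The full size of the step stays open because its starting point is such a limit: the limit of > 30000 nM in this assay, at which 1 of the 4 values shown sits.

Open, as far as these compounds go, is whether the ring nitrogens or the five-membered ring itself accounts for the step. Also open, from the compounds shown here alone, is what an amine or a carboxylic acid would give at this place.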